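Naphthyl semicarbazones: fluoro for bromo on the aryl ring

A few compounds are considered here, and "the series" means these few. Any claim that something is new, unique, unknown or untested is made for them only; others in the source may bear on it.

Measured so far in a functional assay on the whole organism (strain Swiss albino) with Mus musculus as the target, with a stated time of 0.5 h; on this read-out lower numbers stand for an effect already at smaller amounts and higher numbers for an effect only at larger amounts of compound:
- compound 1 `O=C(N/N=C/c1ccc(Br)cc1)Nc1cccc2ccccc12`: 300 mg/kg
- compound 2 `O=C(N/N=C/c1ccccc1[N+](=O)[O-])Nc1cccc2ccccc12`: 300 mg/kg
- compound 3 `COc1cc(/C=N/NC(=O)Nc2cccc3ccccc23)cc(OC)c1OC`: 100 mg/kg

All three share the same core, differing only in the substituted aryl ring attached to the imine. Compound 1 stands level with compound 2 at the digits recorded, and together these two carry the highest numbers of the set. Compound 3 gives a number that is lower than that of compound 1, and this gap lies beyond the usual scatter of this assay. For the measured compounds named here, no pair of these three differs in only one place, so no single step between measured compounds can be read off.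

The next compound, compound 4 `O=C(N/N=C/c1ccc(F)cc1)Nc1cccc2ccccc12`, differs from compound 1 as follows: fluoro in place of bromo on an aromatic carbon. The group that leaves and the group that enters are each a single heavy atom, carry no ring, no hydrogen-bond donors or acceptors and no net charge, and both sit on an aromatic carbon of the same six-membered aromatic ring of carbon only.

With nothing measured for such an exchange within this set, the step of no change at the digits printed from compound 1 to compound 4 (within the scatter) is expected to fall within the scatter, in no clear direction. Compound 4 is therefore estimated at 300 mg/kg, with a range from 100 mg/kg to 600 mg/kg.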

Compound 4, minimum effective dose: 300 mg/kg
For compound 4 middle estimate and measured number coincide at the digits printed; the range from low to high includes it.
By their numbers in this assay, from the lowest: compound 3; then compounds 1, 2 and 4 (each within the scatter of the next).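

In this assay, for the compounds shown here, the step of no change at the digits printed from compound 1 to compound 4 (within the scatter) is the only one so far that isolates a single place, and it shows that exchanging bromo for fluoro on the aromatic carbon para to a large group leaves the minimum effective dose unresolved from that of the parent. Going by these compounds alone, at this place, then, the 4-bromophenyl and 4-fluorophenyl forms of the shared core cannot be told apart on this read-out, a statement that the earlier compounds, all differing in more than one place, could not support. No measurement at hand bears on why these two groups read alike.

As far as these compounds go, whether this place responds to any exchange stays open, since an amine, a carboxylic acid, a methyl group or a longer chain on the same carbon could read quite differently from the two halogens seen here. Also open, from the compounds shown here alone, is whether fluoro in place of bromo would read the same on another carbon of the ring, or on a core carrying other substituents.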